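Adding a chloro to compound 3

The source may hold more compounds than are shown below. What is called first, only, known or untested is meant among the compounds shown, and "the series" means these compounds.

Measured in a functional assay on L02 cells (Homo sapiens) for inhibition, read by MTT assay, with a stated time of 72 h; a higher number here means a weaker inhibitor, a lower number a stronger inhibitor:
compound 1 `C=C(c1ccc(Cl)c(Cl)c1Cl)C1COC2(CCCC2)OO1` gives 1190 nM
compound 2 `C=C(c1ccc(OC)c(F)c1)C1COC(C)(C)OO1` gives > 100000 nM
compound 3 `C=C(c1ccc(Cl)c(Cl)c1)C1COC(C)(C)OO1` gives 50900 nM

The reading for compound 2 (> 100000 nM) is a limit of this assay, not a number. Of the two actual numbers, the higher belongs to compound 3 (50900 nM), not to compound 1 (1190 nM), and the gap between them lies well beyond the scatter.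

Compound 4 `C=C(c1ccc(Cl)c(Cl)c1Cl)C1COC(C)(C)OO1` has chloro in place of hydrogen on an aromatic carbon of compound 3 (chloro in place of hydrogen on an aromatic carbon). Compound 1 (1190 nM) shares this chloro but also differs from compound 4 elsewhere, so only part of its gap is expected to carry over. The expected step (a 2.5-fold lower number from compound 3 to compound 4 (0.41 log units; beyond the scatter)) is a modest fall in the number, slightly beyond the scatter. Compound 4 is estimated at 20000 nM (expected range 6000 nM to 60000 nM).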

Compound 4, half-maximal inhibitory concentration: 18100 nM
The estimate for compound 4 lay 1.1-fold (0.04 log units) above the measured number; low and high end bracket the measured number.
By their numbers in this assay, from the lowest: compound 1; then compound 4; then compound 3. At a limit, above all of these: compound 2.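

In this assay, among these compounds, chloro in place of hydrogen on an aromatic carbon, ortho to a chloro group and ortho to a large group, gives a 2.8-fold lower number from compound 3 to compound 4 (0.45 log units; beyond the scatter), the first single change that can be read. The step is modest: compound 4 gives 18100 nM and remains far from compound 1 at 1190 nM in this series. Nothing shown gives a cause for the step. Open, as far as these compounds go, is how a methyl, a bromo or an amine at this position would compare with the chloro. Also open, from the compounds shown here alone, is whether the chloro step carries over to the core of compound 1.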